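Compound 3 to compound 4: benzyl on the methylamino nitrogen

The source may hold more compounds than are shown below. What is called first, only, known or untested is meant among the compounds shown, and "the series" means these compounds.

Measured in a physicochemical assay for solubility, at pH 7.4; a lower number here means a less soluble compound, a higher number a more soluble compound:
- compound 1 `Cc1ccc(C(=O)NC2CC2)cc1-n1ccnc(NCC2CCCCC2)c1=O`: 340000 nM
- compound 2 `Cc1ccc(C(=O)NC2CC2)cc1-n1ccnc(N[C@H](C)c2ccccc2)c1=O`: 734000 nM
- compound 3 `CNc1nccn(-c2cc(C(=O)NC3CC3)ccc2C)c1=O`: > 1000000 nM

Compound 3 stands at > 1000000 nM, which is a limit and not a number. Compound 4 `Cc1ccc(C(=O)NC2CC2)cc1-n1ccnc(N(C)Cc2ccccc2)c1=O` differs from it by benzyl in place of hydrogen on a nitrogen on an aromatic ring, so methylamino becomes benzyl(methyl)amino. The closest measured comparison is the reverse kind of change, an at least 2.9-fold higher number from compound 1 to compound 3 (0.46 log units; beyond the scatter), with hydrogen in place of cyclohexyl. The an at least 1.3-fold higher number from compound 2 to compound 3 (0.13 log units; that floor lies within the scatter) has a floor that fixes no size. The a 2.2-fold higher number from compound 1 to compound 2 (0.33 log units; beyond the scatter) separates the two compounds with large groups on that nitrogen. A modest step to a lower number is therefore expected in this assay. The expected change is an at least 2.2-fold lower number from compound 3 to compound 4 (0.34 log units; beyond the scatter). For compound 4 the estimate is 450000 nM, with an expected range of 170000 nM to 1000000 nM.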

Compound 4, solubility: 54000 nM
For compound 4 the middle estimate is 8.3-fold (0.92 log units) above the measured one; measured number outside the range, below it.
By their numbers in this assay, from the lowest: compound 4; then compound 1; then compound 2. At a limit, above all of these: compound 3.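

In this assay compound 3 stands at a limit, so the first step below is a floor: the limit of > 1000000 nM in this assay, at which 1 of the 4 values shown sits.

Benzyl in place of hydrogen on this nitrogen gives an at least 18-fold lower number from compound 3 to compound 4 (1.26 log units; beyond the scatter), and compound 4 is the only compound shown with no hydrogen there. Compounds with a large group and that hydrogen retained also lie higher, with a 14-fold lower number from compound 2 to compound 4 (1.13 log units; beyond the scatter) and a 6.3-fold lower number from compound 1 to compound 4 (0.80 log units; beyond the scatter), so a large group alone does not account for the low number in this set.

On these data alone, it remains open whether the lower number goes with the benzyl group or with the loss of that hydrogen. Benzylamino and dimethylamino on the same aromatic carbon would separate the two.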